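The compounds below may be only part of what the source reports. "The series", "measured", "known", "first", "only" and "open" are said of these compounds alone.

Measured values in a physicochemical assay for solubility, using the shake flask method, in phosphate buffer, with a stated time of 24 h, at pH 7.4; on this read-out higher numbers stand for higher solubility and lower numbers for lower solubility:
- compound 1 `Cn1ccc2c(=O)n(-c3ccccc3)c(SCc3cccc(F)c3)nc21` gives 23000 nM 
- compound 2 `CC(Sc1nc2c(cnn2C)c(=O)n1-c1ccccc1)c1cccnc1` gives 209000 nM 
- compound 3 `CC(Sc1nc2c(cnn2C)c(=O)n1-c1ccccc1)c1cccc(O)c1` gives 21000 nM 

Compound 3 lies within the scatter of compound 1, and well under compound 2. Compound 4 `CC(Sc1nc2c(cnn2C)c(=O)n1-c1ccccc1)c1ccccc1` carries hydrogen in place of hydroxy on an aromatic carbon. Going by the values given here, only one measured step touches this aromatic group, 3-hydroxyphenyl in place of pyridin-3-yl, and it is a 10-fold lower number from compound 2 to compound 3 (1.00 log units; beyond the scatter). Among the compounds with values here, that step bears only loosely, since no measured pair removes a hydroxy alone. A smaller shift towards a lower number is therefore expected in this assay, with an estimated step of a 2.3-fold lower number from compound 3 to compound 4 (0.37 log units; beyond the scatter) as the best guess. For compound 4 the estimate is 9000 nM, with an expected range from 2500 nM to 30000 nM for the coming measurement.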

Compound 4, solubility: 8000 nM
The estimate for compound 4 lay 1.1-fold (0.05 log units) above the measured number, and the stated range covers the measured number.
By their numbers in this assay, from the lowest: compound 4; then compounds 3 and 1 (each within the scatter of the next); then compound 2.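

In this assay the hydroxy can now be read alone: there is a 2.6-fold lower number from compound 3 to compound 4 (0.42 log units; beyond the scatter) when hydrogen takes its place on the aromatic carbon. The larger step is a 26-fold lower number from compound 2 to compound 4 (1.42 log units; beyond the scatter) with phenyl in place of pyridin-3-yl, so among these three groups, phenyl gives the lowest number and pyridin-3-yl the highest. No supporting data explain why these numbers move.

Still open, on these data alone, is what an amine or a carboxylic acid in place of the hydroxy would give in this assay and whether these steps would hold on the core of compound 1.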